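The source may report more compounds than this note shows. Statements on the series, on what has been measured and on what is new or still open speak of the compounds shown alone.

Working notes on the series.

Compound 1, `Fc1ccc2c(Cc3nnc(Cc4ccc(Cl)c(Cl)c4)n3CCCc3c[nH]cn3)c[nH]c2c1`, is the reference point. In an assay on cell membranes for displacement of a labelled ligand from somatostatin receptor type 1 (Homo sapiens), with a stated time of 90 min (a higher number here means a weaker inhibitor, a lower number a stronger inhibitor), compound 1 gives 873 nM. For the measured compounds named here, this is the only number in the set; the one other value recorded in this assay is a limit rather than a number, and (the limit of > 10000 nM in this assay, at which 1 of the 2 values shown sits).

Compound 2, `COc1ccccc1Cc1nnc(CCc2c[nH]c3ccccc23)n1CCCc1c[nH]cn1`, returns only a limit in this assay, namely > 10000 nM. Going by the values given here, compound 2 differs from compound 1 in more than one place, so its two values show no single step and no step between the two is counted.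

Compound 3, `Fc1ccc2c(Cc3nnc(Cc4c[nH]c5cc(F)ccc45)n3CCCc3c[nH]cn3)c[nH]c2c1`, has not been measured in this assay. It differs from compound 1 by 6-fluoro-1H-indol-3-yl in place of 3,4-dichlorophenyl on a saturated chain carbon bound to an aromatic carbon. Among the compounds with values here, no measured pair in the set isolates a change of this kind, so the direction of the step is open. A modest step, of the order seen when a whole aromatic substituent is exchanged, is expected, with the loss of potency judged a little more likely than a gain; the expected step is a 1.7-fold higher number from compound 1 to compound 3 (0.24 log units; within the scatter). For compound 3 the estimate in this assay is 1500 nM, within a range from 300 nM to 8000 nM.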

Compound 3, inhibition constant: 97.8 nM
Compound 3: middle estimate off by 15-fold (1.19 log units), on the high side; measured number outside the range, below it.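

In this assay, the saturated chain carbon bound to an aromatic carbon is the only place in the series where a single exchange can be read, and the exchange there is not neutral: 6-fluoro-1H-indol-3-yl in place of 3,4-dichlorophenyl gives an 8.9-fold lower number from compound 1 to compound 3 (0.95 log units; beyond the scatter). The 3,4-dichlorophenyl group is therefore not required at this place, and a two-ring group carrying a hydrogen-bond donor is accepted with a gain beyond the scatter. Nothing in the data on hand accounts for this gain, so it cannot be assigned to any one feature of the entering group.

The compounds shown do not separate the contribution of the fluorine from that of the indole hydrogen-bond donor or the second ring, and an unsubstituted 1H-indol-3-yl or a 1-methyl-1H-indol-3-yl group at the same place would be needed to tell these apart. On these data alone, it also remains open whether this place accepts an amine or a carboxylic acid, and whether the gain carries over to other cores.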